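A Single Nitrogen Change and Its Expected Clearance

A few compounds are considered here, and "the series" means these few. Any claim that something is new, unique, unknown or untested is made for them only; others in the source may bear on it.

Three compounds have so far been run in an ADME assay on microsomes from liver (Homo sapiens) for metabolic stability; on this read-out higher numbers stand for fast clearance and lower numbers for slow clearance. Compound 1 `COc1ccccc1CCOc1cncc2nnc(CC(C)C)n12` gives a value that is a limit of the assay rather than a number, > 287 mL/min/kg, and this is recorded as the limit of > 287 mL/min/kg in this assay, at which 1 of the 3 values shown sits. Compound 2 `Cn1ncc(-c2nn(C)c3ncnc(N4CCC4)c23)c1-c1ccc(C2CC2)cn1` gives 53 mL/min/kg in this assay. Compound 3 `CCc1ccc(-c2c(-c3nn(C)c4ncnc(N5CCCC5)c34)cnn2C)cc1` gives 200 mL/min/kg in this assay. Among the two numbers that are not limits, compound 2 stands lowest, and compound 3 sits at a higher number by a gap that lies beyond the usual scatter of repeated measurements.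

Compound 4 `Cn1ncc(-c2nn(C)c3ncnc(N4CCC4)c23)c1-c1ncc(C2CC2)cn1` has not yet been measured. Compared with compound 2 it differs in one place: 5-cyclopropylpyrimidin-2-yl in place of 5-cyclopropylpyridin-2-yl on an aromatic carbon. Among the measured compounds shown here, no pair of measured compounds that differ in a single place is available, so this step has no direct precedent in the data and its size cannot be read from a measured pair.

Compound 4 is expected to give 40 mL/min/kg in this assay, with a range from 20 mL/min/kg to 90 mL/min/kg. The step that this estimate means, a 1.3-fold lower number from compound 2 to compound 4 (0.12 log units; within the scatter), is expected to stay within the usual scatter, leaning if anything toward slower clearance.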

Compound 4, clearance: 28 mL/min/kg
Estimate against measurement, compound 4: 1.4-fold (0.15 log units) above; the measured number falls inside the stated range.
By their numbers in this assay, from the lowest: compounds 4 and 2 (each within the scatter of the next); then compound 3. At a limit, above all of these: compound 1.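

Among the compounds shown here, the pair gives the first single-place step in this assay, and it is a 1.9-fold lower number from compound 2 to compound 4 (0.28 log units; within the scatter), so the size of this exchange can now be read directly rather than inferred. On an aromatic carbon of a five-membered aromatic ring with 2 nitrogen, 5-cyclopropylpyrimidin-2-yl in place of 5-cyclopropylpyridin-2-yl adds one ring nitrogen and one hydrogen-bond acceptor by count, yet compound 2 and compound 4 cannot be told apart on this read-out. Nothing measured in this set gives a reason for the size of this step.

This single step cannot show whether the same exchange of rings would stay as small with a tert-butyl group or a nitrile in place of the cyclopropyl group, or with a different group on the shared core. From the compounds shown here alone, whether an amine or a carboxylic acid on the six-membered aromatic ring at this position would carry the clearance read-out beyond the scatter also remains open.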